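The compounds below may be only part of what the source reports. "The series", "measured", "known", "first", "only" and "open" are said of these compounds alone.

Compound 1 `O=C(Nc1cccc(/C=C/C(=O)c2nc3ccccc3[nH]2)c1)c1ccccc1`: 8340 nM
Compound 2 `O=C(Nc1cccc(/C=C/C(=O)c2nc3ccccc3[nH]2)c1)c1ccc(Cl)cc1`: 7440 nM
Compound 3 `Cc1ccccc1C(=O)Nc1cccc(/C=C/C(=O)c2nc3ccccc3[nH]2)c1`: 8290 nM

The three compounds were measured in a functional assay on 143B cells (Homo sapiens) for antiproliferative activity, read by MTT assay, with a stated time of 48 h; on this read-out lower numbers stand for stronger inhibition and higher numbers for weaker inhibition. Compound 1 sits at one end of the three numbers, but the steps of a 1.1-fold lower number from compound 1 to compound 2 (0.05 log units; within the scatter) and a 1.0-fold lower number from compound 1 to compound 3 (0.00 log units; within the scatter) show that all three lie within the usual scatter of one another, as does the step of a 1.1-fold higher number from compound 2 to compound 3 (0.05 log units; within the scatter). In plain terms, putting chloro or methyl onto the benzoyl ring changed nothing that can be told apart from noise.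

Compound 4 `O=C(/C=C/c1cccc(NS(=O)(=O)c2ccccc2Cl)c1)c1nc2ccccc2[nH]1` has not yet been measured. Compared with compound 1, the change is (2-chlorophenyl)sulfonyl in place of benzoyl on a nitrogen on an aromatic ring. Among the measured compounds shown here, no measured step covers this swap of the amide link for a sulfonamide; the only steps at hand, from compound 1 to compound 2 and to compound 3, alter the ring that leaves and were within the scatter. The chlorine that enters has a loose parallel in the chloro of compound 2, which also made no difference beyond the scatter.

With nothing in the data to point either way, compound 4 is expected to give about 7500 nM in this assay, with a range from 3000 nM to 18000 nM. This estimate means a step of a 1.1-fold lower number from compound 1 to compound 4 (0.05 log units; within the scatter) that is expected to stay within the scatter.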

Compound 4, half-maximal inhibitory concentration: 4790 nM
Estimate against measurement, compound 4: 1.6-fold (0.19 log units) above; the range from low to high includes it.
By their numbers in this assay, from the lowest: compounds 4, 2, 3 and 1 (each within the scatter of the next).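

In this assay, putting (2-chlorophenyl)sulfonyl in place of benzoyl on the nitrogen gives a 1.7-fold lower number from compound 1 to compound 4 (0.24 log units; within the scatter). Among the compounds shown here, this change replaces the carbonyl link itself, whereas the earlier steps only added a small group to the ring, yet it still stays within the scatter, as do a 1.7-fold lower number from compound 3 to compound 4 (0.24 log units; within the scatter) and a 1.6-fold lower number from compound 2 to compound 4 (0.19 log units; within the scatter). For these compounds, then, a sulfonyl link can stand in for a carbonyl link on this nitrogen with no difference that can be told apart from noise, and no measurement at hand offers an explanation for this outcome.

Compound 4 changes the link and brings in the chlorine in a single step, and a plain phenylsulfonyl group on the same nitrogen would be needed to tell those two changes apart. Going by these compounds, it also remains open whether this position would accept groups of a quite different kind just as quietly, such as a ring carrying an amine or a carboxylic acid, or a longer chain between the sulfonyl and the ring.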